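Second chloro on the fused core of a chloromethylbenzyl series

The compounds below may be only part of what the source reports. "The series", "measured", "known", "first", "only" and "open" are said of these compounds alone.

Three compounds of a shared core have numbers in a functional assay on UO-31 cells (Homo sapiens) for cytotoxicity, read by sulforhodamine B assay, with a stated time of 48 h; a higher number here means a weaker inhibitor of growth, a lower number a stronger inhibitor of growth. Compound 1 `ClCc1ccc(Cn2cnc3c(Cl)ncnc32)cc1` gives 2080 nM in this assay. Compound 2 `ClCc1cccc(Cn2cnc3c(Cl)nc(Cl)nc32)c1` gives 1580 nM in this assay, and compound 3 `ClCc1ccccc1Cn1cnc2nc(Cl)nc(Cl)c21` gives 1730 nM. The three numbers sit within the usual scatter of one another, so compound 1 cannot be told apart from compound 2 or compound 3 on these data; no ordering among the three is supported.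

Compound 4 `ClCc1ccc(Cn2cnc3c(Cl)nc(Cl)nc32)cc1` is not yet measured in this assay. Relative to compound 1 the change is chloro in place of hydrogen on an aromatic carbon. Compounds 2 and 3 already carry a second chloro on their core, and both of their numbers lie within the scatter of the number of compound 1. Within the data shown here, no pair of measured compounds differs in a single place, so no measured step is available for this change; the only guide is that the dichloro compounds 2 and 3 and the monochloro compound 1 are indistinguishable here.

The step from compound 1 to compound 4 is expected to be small and within the scatter, a 1.2-fold lower number from compound 1 to compound 4 (0.08 log units; within the scatter). Compound 4 is therefore estimated at 1750 nM in this assay, with a range from 900 nM to 3400 nM.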

Compound 4, concentration for 50% growth inhibition: 19500 nM
Estimate against measurement, compound 4: 11-fold (1.05 log units) below; measured number outside the range, above it.
By their numbers in this assay, from the lowest: compounds 2, 3 and 1 (each within the scatter of the next); then compound 4.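

Among these compounds, on the aromatic carbon of the core of compound 1, between two ring nitrogen atoms, chloro in place of hydrogen is not a silent change in this assay: it gives a 9.4-fold higher number from compound 1 to compound 4 (0.97 log units; beyond the scatter), a shift towards weaker inhibition of growth that the earlier compounds gave no sign of. A second chloro on the core does not by itself set a high number: compound 4 differs from compound 2, which carries the same chloro, only in where the chloromethyl group sits on the benzyl ring, and compound 4 gives (19500 nM) while compound 2 gives (1580 nM), so the effect of this chloro may depend on the placing of the chloromethyl group. Nothing available on these compounds bears on why this step is as large as it is.

The compounds shown leave open whether an amine or a methoxy group on this same carbon would follow the chloro or the hydrogen. They also leave open how large the step from hydrogen to chloro would be with the chloromethyl group placed as in compound 2, where the partner carrying hydrogen is absent from this set.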